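Pyrrole to Thiophene: Expecting Another Limit

A few compounds are considered here, and "the series" means these few. Any claim that something is new, unique, unknown or untested is made for them only; others in the source may bear on it.

Compound 1 `CC1=CC[C@H](C(C)(C)NC(=S)N/N=C/c2cccc(Cl)c2)CC1`: in a functional assay on K562 cells (Homo sapiens) for inhibition, read by sulforhodamine B assay, with a stated time of 48 h (on this read-out higher numbers stand for weaker inhibition of growth and lower numbers for stronger inhibition of growth), compound 1 reaches only the assay limit > 100000 nM.
Compound 2 `CC1=CC[C@H](C(C)(C)NC(=S)N/N=C/c2ccc[nH]2)CC1`: in this assay compound 2 reaches only the assay limit > 100000 nM.

Both measured values are limits, so the step that the two limits leave unreadable from compound 1 to compound 2 cannot be read, and compound 2 stands simply at the limit. Compound 3 `CC1=CC[C@H](C(C)(C)NC(=S)N/N=C/c2cccs2)CC1` differs from compound 2 by thiophen-2-yl in place of 1H-pyrrol-2-yl on a carbon with a double bond to nitrogen. Among the measured compounds shown here, the one measured step bears on this change but gives no size, and both values sit at the limit of > 100000 nM in this assay, at which 2 of the 2 values shown sit. The expected step that the limit leaves unreadable from compound 2 to compound 3 is therefore none beyond the scatter. Compound 3 is estimated at 120000 nM, between 30000 nM and 400000 nM, most likely again reported only as a limit.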

Compound 3, concentration for total growth inhibition: > 100000 nM
Compound 3: no number, only a limit (the forecaster's own chance of this, stated with the estimate: 80%); the middle value is on the limit's open side.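

Compound 3, like compound 1 and compound 2, gives only a limit, so no step among these compounds can be read: the limit of > 100000 nM in this assay, at which 3 of the 3 values shown sit. From the compounds shown here alone, how strongly they inhibit growth in this assay and whether 3-chlorophenyl, 1H-pyrrol-2-yl and thiophen-2-yl differ at all stay open.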